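The source may hold more compounds than are shown below. What is called first, only, known or untested is meant among the compounds shown, and "the series" means these compounds.

Measured compounds in a physicochemical assay for solubility, with a stated time of 18 h, at pH 7.4; a higher number here means a more soluble compound, a lower number a less soluble compound:

- compound 1 `COc1cccc(CNCCCNc2ccnc3cc(-c4ccc(C(F)(F)F)cc4)ccc23)c1O`: 32000 nM
- compound 2 `COc1cccc(CNCCCNc2ccnc3cc(-c4ccccc4)ccc23)c1O`: 32000 nM
- compound 3 `COc1cccc(CNCCCNc2ccnc3cc(Oc4cccc(N(C)C)c4)ccc23)c1O`: 14500 nM

Compound 3 gives the lowest solubility of the three; its nearest neighbour is compound 1, a 2.2-fold lower number from compound 1 to compound 3 (0.34 log units; beyond the scatter), and compound 2 sits at the same distance, a 2.2-fold lower number from compound 2 to compound 3 (0.34 log units; beyond the scatter). Compound 1 and compound 2 are within the scatter of each other, no change at the digits printed from compound 1 to compound 2 (within the scatter).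

Compound 4 `COc1cccc(CNCCCNc2ccnc3cc(C4CCCCC4)ccc23)c1O` is not yet measured. Relative to compound 3 the change is cyclohexyl in place of 3-(dimethylamino)phenoxy on an aromatic carbon. Among the measured compounds shown here, no measured step covers this exact exchange. For the measured compounds named here, the steps that bear on it are the two that lead into compound 3: both replace a carbon-linked six-membered aromatic ring with the 3-(dimethylamino)phenoxy group and both give a modest drop, a 2.2-fold lower number from compound 1 to compound 3 (0.34 log units; beyond the scatter) and a 2.2-fold lower number from compound 2 to compound 3 (0.34 log units; beyond the scatter). Removing that group again in compound 4 is therefore expected to recover a step of similar size in the opposite direction, a 1.8-fold higher number from compound 3 to compound 4 (0.25 log units; within the scatter), with wide uncertainty since cyclohexyl is new to the set. The estimated solubility of compound 4 in this assay is 26000 nM, with a range from 10000 nM to 60000 nM.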

Compound 4, solubility: 4200 nM
The estimate for compound 4 lay 6.2-fold (0.79 log units) above the measured number; measured number below the stated range.
By their numbers in this assay, from the lowest: compound 4; then compound 3; then compounds 1 and 2 (each within the scatter of the next).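

In this assay the position takes a clear penalty from a saturated ring: on the shared core, cyclohexyl in place of the aromatic ring gives a 7.6-fold lower number from compound 2 to compound 4 (0.88 log units; beyond the scatter), and the comparison with 4-(trifluoromethyl)phenyl gives the same size of step, a 7.6-fold lower number from compound 1 to compound 4 (0.88 log units; beyond the scatter). Compound 3 therefore no longer marks the low end of the set, since leaving 3-(dimethylamino)phenoxy for the smaller cyclohexyl, with fewer heavy atoms and no hydrogen-bond acceptors, gives a 3.5-fold lower number from compound 3 to compound 4 (0.54 log units; beyond the scatter) rather than a recovery. No measurement at hand gives a cause for these steps.

As far as these compounds go, whether a cyclopentyl ring or a cyclohexyl ring bearing an amine would fall with compound 4 stays open. So does whether an unsubstituted phenoxy would sit with compound 3 or with the carbon-linked aromatic rings.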